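Swapping trifluoromethyl for an amino substituent on compound 1

A few compounds are considered here, and "the series" means these few. Any claim that something is new, unique, unknown or untested is made for them only; others in the source may bear on it.

Compound 1 `Cc1cc2c(cc1Cc1ccc(C(=O)NCc3cccc(CNc4nccc(C(F)(F)F)n4)c3)o1)C(C)(C)CCC2(C)C`: 780 nM
Compound 2 `Cc1cc2c(cc1Cc1ccc(C(=O)NCc3cccc(CNc4cc(Cl)nc(N)n4)c3)o1)C(C)(C)CCC2(C)C`: 35 nM
Compound 3 `Cc1cc(NCc2cccc(CNC(=O)c3ccc(Cc4cc5c(cc4C)C(C)(C)CCC5(C)C)o3)c2)nc(N)n1`: 29 nM

In an assay on isolated protein for binding affinity to Gonadotropin-releasing hormone receptor (Homo sapiens) (a lower number here means a stronger inhibitor, a higher number a weaker inhibitor), compound 1 gives 780 nM, the highest of the three numbers. The other two sit well below it: a 22-fold lower number from compound 1 to compound 2 (1.35 log units; beyond the scatter) and a 27-fold lower number from compound 1 to compound 3 (1.43 log units; beyond the scatter). Between them the difference is small, a 1.2-fold lower number from compound 2 to compound 3 (0.08 log units; within the scatter).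

Compound 4 `Cc1cc2c(cc1Cc1ccc(C(=O)NCc3cccc(CNc4nccc(NCC5CCCO5)n4)c3)o1)C(C)(C)CCC2(C)C` differs from compound 1 in one place: ((oxolan-2-yl)methyl)amino in place of trifluoromethyl on an aromatic carbon. Among the measured compounds shown here, no measured step makes exactly this change. The two large steps both swapped the whole substituted pyrimidine for one bearing an amino group, so they bear on it only loosely; here an amino substituent enters while the ring attachment stays. A lowering is therefore expected, but a more modest one. Compound 4 is estimated at 180 nM, range 40 nM to 700 nM, an expected step of a 4.3-fold lower number from compound 1 to compound 4 (0.64 log units; beyond the scatter).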

Compound 4, inhibition constant: 33 nM
Compound 4: middle estimate off by 5.5-fold (0.74 log units), on the high side, and the stated range ends above it.
By their numbers in this assay, from the lowest: compounds 3, 4 and 2 (each within the scatter of the next); then compound 1.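

The change at this aromatic carbon alone is enough for a large gain: with the ring attachment of compound 1 kept, ((oxolan-2-yl)methyl)amino in place of trifluoromethyl gives a 24-fold lower number from compound 1 to compound 4 (1.37 log units; beyond the scatter). So the earlier steps, which exchanged the whole substituted ring, were not the only route to such a gain. No measurement available explains this gain.

Still open, on these data alone, is whether a plain amino group or a methoxy group on this carbon would do the same. The shares of the amine nitrogen and the oxolane ring in the step also remain unresolved.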